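Regiochemistry of the Chlorotrifluoromethylphenyl Urea Arm

The source may report more compounds than this note shows. Statements on the series, on what has been measured and on what is new or still open speak of the compounds shown alone.

Measured compounds:
compound 1, `CC(NC(=O)/C=C/Oc1ccc(NC(=O)Nc2cc(C(F)(F)F)ccc2Cl)cc1)c1ccccc1`, > 50000 nM
compound 2, `CNC(=O)C#Cc1ccc(NC(=O)Nc2ccc(Cl)c(C(F)(F)F)c2)cc1`, 14000 nM
compound 3, `O=C(CCc1ccc(NC(=O)Nc2ccc(Cl)c(C(F)(F)F)c2)cc1)NC1CCC1`, 21300 nM

Of the compounds shown here, three have been measured in a functional assay on HT-29 cells (Homo sapiens) for inhibition, read by MTT assay, with a stated time of 120 h; on this read-out lower numbers stand for stronger inhibition and higher numbers for weaker inhibition. Compound 2 gives 14000 nM and compound 3 gives 21300 nM; the step of a 1.5-fold higher number from compound 2 to compound 3 (0.18 log units; within the scatter) lies within the scatter. Compound 1 stands apart. For compound 1 the assay reports only a limit, > 50000 nM, and no number, a fact recorded in the limit of > 50000 nM in this assay, at which 1 of the 3 values shown sits.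

Compound 4, `CC(NC(=O)/C=C/Oc1ccc(NC(=O)Nc2ccc(Cl)c(C(F)(F)F)c2)cc1)c1ccccc1`, shares the shared core of compound 1 and differs from it in one place, (4-chloro-3-(trifluoromethyl)phenyl in place of 2-chloro-5-(trifluoromethyl)phenyl on an amide-type nitrogen). Going by the values given here, no measured step covers this rearrangement: the only step at hand, from compound 2 to compound 3, changes a different part of the molecule. Among the compounds with values here, what can be said is that the aryl group entering compound 4 is the one carried by compound 2 and compound 3, both of which give a number in this assay.

Compound 4 is therefore expected to give a number rather than a limit, estimated at 20000 nM with a range from 5000 nM to 80000 nM. The expected step of an at least 2.5-fold lower number from compound 1 to compound 4 (0.39 log units; beyond the scatter) cannot be sized against the limit of compound 1.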

Compound 4, half-maximal inhibitory concentration: > 50000 nM
Compound 4: no number, only a limit; the forecaster's own chance of this, stated with the estimate: 30%; middle value at least 2.5-fold (0.39 log units) away from the limit.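

In this assay compound 4 gives > 50000 nM, a limit and not a number. Going by these compounds alone, compound 1 also sits at a limit, so no step between compound 1 and compound 4 can be read. The compounds shown leave open how 4-chloro-3-(trifluoromethyl)phenyl and 2-chloro-5-(trifluoromethyl)phenyl compare on this shared core.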